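Sulfur-bearing group on the chain nitrogen: compound 4

The compounds below may be only part of what the source reports. "The series", "measured", "known", "first", "only" and "open" are said of these compounds alone.

Among the measured compounds shown here, compound 1 `C/N=C(/NC#N)NCCCn1nc(-c2ccccc2)ccc1=O` gives 78.1 mg/kg in a functional assay on the whole organism with Rattus norvegicus as the target (on this read-out higher numbers stand for an effect only at larger amounts of compound and lower numbers for an effect already at smaller amounts), the highest of the three numbers measured so far. Compound 2 `CC/N=C(/NC#N)NCCCCn1nc(-c2ccccc2)ccc1=O` gives 60.7 mg/kg in this assay, which lies within the scatter of compound 1. For the measured compounds named here, compound 3 `NC(=O)SCCCCCN1NC=CC=C1c1ccccc1` gives 18.3 mg/kg in this assay, a lower number than compound 1 and beyond the scatter; no single-point step connects these two structures, so only the two values themselves can be compared. Compound 4 `C/N=C(\S)NCCCn1nc(-c2ccccc2)ccc1=O` differs from compound 1 in one place: a group of 4 heavy atoms (2 carbon, 1 nitrogen, 1 sulfur; no ring) in place of a group of 6 heavy atoms (3 carbon, 3 nitrogen; no ring), on an amine nitrogen. Going by the values given here, no measured pair shows this exchange, so its size is unknown. The expectation for compound 4 is a modest move to a lower number, a 1.6-fold lower number from compound 1 to compound 4 (0.19 log units; within the scatter), near the edge of the scatter. In this assay compound 4 is estimated at 50 mg/kg, with a range from 22 mg/kg to 115 mg/kg.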

Compound 4, dose for half-maximal effect: 58 mg/kg
Compound 4: the middle estimate sits 1.2-fold (0.06 log units) below what was measured; measured number inside the range.
By their numbers in this assay, from the lowest: compound 3; then compounds 4, 2 and 1 (each within the scatter of the next).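

Among the compounds shown here, this is the first exchange readable at the amine nitrogen: in this assay, the step is a 1.3-fold lower number from compound 1 to compound 4 (0.13 log units; within the scatter). The group of 4 heavy atoms therefore stands in for the group of 6 heavy atoms, losing the triple bond, without the read-out separating the two. Nothing available bears on what lies behind this result.

Open, going by these compounds, is whether a plain amine or a carboxylic acid at this place would give a step beyond the scatter. Also open, on these data alone, is how a longer chain would read with the sulfur-bearing group in place.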